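The source may hold more compounds than are shown below. What is called first, only, known or untested is meant among the compounds shown, and "the series" means these compounds.

Compound 1 `O=c1cc(-c2ccccc2)oc2ccc(OCCCCCCN3CCC(O)CC3)cc12`: 100 nM
Compound 2 `O=c1cc(-c2cccnc2)oc2ccc(OCCCCCCN3CCC(O)CC3)cc12`: 194 nM
Compound 3 `O=c1cc(-c2ccc(F)cc2)oc2ccc(OCCCCCCN3CCC(O)CC3)cc12`: 95 nM

These three compounds share one core and were tested in an assay on isolated protein (Cavia porcellus) with Sigma non-opioid intracellular receptor 1 (Homo sapiens) as the target, read by radioligand binding; on this read-out higher numbers stand for weaker inhibition and lower numbers for stronger inhibition. Compound 2 carries pyridin-3-yl where compound 1 carries phenyl and compound 3 carries 4-fluorophenyl. Compound 2 has the highest of the three numbers, but the gaps are small: a 1.9-fold higher number from compound 1 to compound 2 (0.29 log units; within the scatter), while a 2.0-fold lower number from compound 2 to compound 3 (0.31 log units; beyond the scatter). Compound 4 `O=c1cc(-c2cccnc2)oc2ccc(OCCCCCCN3CCCCC3)cc12` keeps the pyridin-3-yl of compound 2 and changes only the other end of the molecule: hydrogen in place of hydroxy on a saturated ring carbon. For the measured compounds named here, none of the measured steps touches this part of the molecule; all three alter the aromatic group. The measured steps therefore give no guide for this change, and the expectation is a number near that of compound 2, with wide uncertainty. Compound 4 is estimated at 200 nM, range 60 nM to 700 nM, which means an expected step of a 1.0-fold higher number from compound 2 to compound 4 (0.01 log units; within the scatter).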

Compound 4, half-maximal inhibitory concentration: 119 nM
For compound 4 the middle estimate is 1.7-fold (0.23 log units) above the measured one; low and high end bracket the measured number.
By their numbers in this assay, from the lowest: compounds 3, 1, 4 and 2 (each within the scatter of the next, the first and the last beyond it).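

Taking the hydroxy off the ring gives the first look at this end of the molecule: in this assay, the change reads a 1.6-fold lower number from compound 2 to compound 4 (0.21 log units; within the scatter) and so cannot be told apart from ordinary scatter. With pyridin-3-yl in place, the hydroxy on this saturated ring carbon is therefore not required for a number in this range. No measured evidence bears on this result.

As far as these compounds go, whether the same holds with phenyl or 4-fluorophenyl remains open. So does the effect of an amine, a methoxy or a carboxylic acid on this ring carbon.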